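Adding a Methyl to a Short Branched Chain

A few compounds are considered here, and "the series" means these few. Any claim that something is new, unique, unknown or untested is made for them only; others in the source may bear on it.

Three compounds share one core and differ only in the chain attached to a double-bonded nitrogen. Compound 1 `CCCC/N=C(\NC#N)Nc1cccnc1` carries a butyl chain, compound 2 `CC(C)CC/N=C(\NC#N)Nc1cccnc1` an isopentyl chain, and compound 3 `CC(C)/N=C(\NC#N)Nc1cccnc1` an isopropyl chain. All three were tested in a functional assay on the whole organism (blood, strain Wistar-Okamoto) with Rattus norvegicus as the target, with a stated time of 5 days; a lower number here means that less compound is needed, a higher number that more compound is needed for the effect. In this assay compound 1 gives 20 mg/kg, compound 2 gives 20 mg/kg, and compound 3 gives 2.5 mg/kg.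

The change from compound 1 to compound 2 is methyl in place of hydrogen on a saturated chain carbon bound to two saturated chain carbons, and it made no change at the digits printed from compound 1 to compound 2 (within the scatter). Moving to the shorter, branched chain made an 8.0-fold lower number from compound 1 to compound 3 (0.90 log units; beyond the scatter) and also an 8.0-fold lower number from compound 2 to compound 3 (0.90 log units; beyond the scatter), so compound 3 stands with the lowest number of the three.

Compound 4 `CCC(C)/N=C(\NC#N)Nc1cccnc1` has not yet been measured. It differs from compound 3 by methyl in place of hydrogen on a saturated chain carbon, two bonds along the chain from a double-bonded nitrogen. The cores of compound 3 and compound 1 differ by isopropyl in place of butyl on a double-bonded nitrogen. The change to compound 4 is the same kind of change as that from compound 1 to compound 2, not the same: in compound 2 the new methyl sits on a saturated chain carbon bound to two saturated chain carbons, whereas in compound 4 it sits on a saturated chain carbon two bonds along the chain from a double-bonded nitrogen.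

The step from compound 3 to compound 4 is expected to be small, a 1.4-fold higher number from compound 3 to compound 4 (0.15 log units; within the scatter), because the earlier methyl addition gave no change at the digits printed from compound 1 to compound 2 (within the scatter). Compound 4 is therefore estimated to give about 3.5 mg/kg, most likely between 1.5 mg/kg and 10 mg/kg.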

Compound 4, minimum effective dose: 20 mg/kg
For compound 4 the middle estimate is 5.7-fold (0.76 log units) below the measured one, outside the stated range (above it).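

In this assay, adding a methyl to the isopropyl chain gave an 8.0-fold higher number from compound 3 to compound 4 (0.90 log units; beyond the scatter), and replacing the longer chains with sec-butyl gave no change at the digits printed from compound 2 to compound 4 (within the scatter) and no change at the digits printed from compound 1 to compound 4 (within the scatter). This shows that a methyl in place of hydrogen did not carry over from one core to the other in this series, so the result on one chain could not be read across to the next: the same change on two cores in this assay, no change at the digits printed (within the scatter) from compound 1 to compound 2 and an 8.0-fold higher number (0.90 log units; beyond the scatter) from compound 3 to compound 4, 8.0-fold (0.90 log units) apart, beyond the scatter of two such steps. It does not show why the two steps part, as the new methyl sits in a different place in each case, and two cases give no rule for any further chain.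

The compounds shown leave open whether the low number in this assay belongs to the isopropyl chain alone or is shared by other groups on the double-bonded nitrogen, such as an ethyl chain, a tert-butyl group or a cyclopropyl ring. They also leave open what a longer chain, or a chain carrying an amine, would give.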